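The source may report more compounds than this note shows. Statements on the series, on what has been measured and on what is new or still open speak of the compounds shown alone.

In an ADME assay on a cell-free system (plasma, Homo sapiens) for protein binding (on this read-out lower numbers stand for a smaller free fraction and higher numbers for a larger free fraction), compound 3 `COc1c(C2CCN(c3ccn4c(CC5CC5)nnc4c3Cl)CC2)ccc(F)c1F` reads < 0.01, which is a limit of the assay and not a number. Compound 1 `COc1ccc(F)cc1C1CCN(c2ccn3c(CC(F)(F)F)nnc3c2Cl)CC1` gives < 0.01, also a limit. Compound 2 `COc1c(F)cccc1C1CCN(c2ccn3c(CC4CC4)nnc3c2Cl)CC1` gives < 0.01, again a limit. The whole picture so far is the limit of < 0.01 in this assay, at which 3 of the 3 values shown sit. Compound 4 `COc1cc(F)cc(F)c1C1CCN(c2ccn3c(CC4CC4)nnc3c2Cl)CC1` differs from compound 3 as follows: 2,4-difluoro-6-methoxyphenyl in place of 3,4-difluoro-2-methoxyphenyl on a saturated ring carbon, with 2,4-difluoro-6-methoxyphenyl in place of 3,4-difluoro-2-methoxyphenyl on a saturated ring carbon. For the measured compounds named here, the one measured step that bears on this is a step that the two limits leave unreadable from compound 2 to compound 3, so it offers neither a size nor a direction. No shift beyond the scatter is therefore expected in this assay, and the expected change is a step that the limit leaves unreadable from compound 3 to compound 4. Compound 4 is estimated at 0.007, with an expected range from 0.003 to 0.015.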

Compound 4, unbound fraction: < 0.01
Compound 4: only a limit was reported; the forecaster's own chance of this, stated with the estimate: 80%; the middle value lies beyond the limit too.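

Neither step, from compound 3 to compound 4 or from compound 2 to compound 4, can be read in this assay, because each pair has only limits to compare: the limit of < 0.01 in this assay, at which 4 of the 4 values shown sit. The compounds shown leave open how their actual unbound fractions compare.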